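Butyl on the amine nitrogen of a butyltellanyl arylethylamine

A few compounds are considered here, and "the series" means these few. Any claim that something is new, unique, unknown or untested is made for them only; others in the source may bear on it.

Measured so far:
- compound 1, `CCCC[Te]c1ccc(C(C)N)cc1`: 12.1 ug/mL
- compound 2, `CCCC[Te]c1ccc(/C(C)=N/O)cc1`: 7.79 ug/mL

Compound 1 carries a primary amine on the carbon attached to the shared core. Going by the values given here, in a functional assay, read by spectrophotometry, with a stated time of 30 min (a lower number here means a stronger inhibitor, a higher number a weaker inhibitor), compound 1 gives 12.1 ug/mL, the highest of the two numbers known here, though the gap to compound 2 is small: the step of a 1.6-fold lower number from compound 1 to compound 2 (0.19 log units; within the scatter) lies within the scatter, so the two cannot be ranked.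

Compound 3, `CCCCNC(C)c1ccc([Te]CCCC)cc1`, differs from compound 1 by one change: butyl in place of hydrogen on an amine nitrogen. Among the compounds with values here, no measured pair shows this change. Within the data shown here, the only step known, from compound 1 to compound 2, swaps the amine for an oxime, which is a change at a different place, and it stayed within the scatter. There is therefore nothing in the numbers pointing either way for a butyl on the amine nitrogen, and the expectation can only be of a step no larger than the scatter.

Compound 3 is expected to give about 10 ug/mL in this assay, with a range from 4 ug/mL to 30 ug/mL, meaning an expected step of a 1.2-fold lower number from compound 1 to compound 3 (0.08 log units; within the scatter) that stays within the scatter.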

Compound 3, half-maximal inhibitory concentration: 8.63 ug/mL
The estimate for compound 3 lay 1.2-fold (0.06 log units) above the measured number, and the stated range covers the measured number.
By their numbers in this assay, from the lowest: compounds 2, 3 and 1 (each within the scatter of the next).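

In this assay, placing butyl instead of hydrogen on the amine nitrogen gives a 1.4-fold lower number from compound 1 to compound 3 (0.15 log units; within the scatter), so compound 1 and compound 3 cannot be ranked. Going by these compounds alone, this is the first direct reading of a change on this nitrogen, as the earlier pair replaced the amine with an oxime and left open what a group on the nitrogen itself would do. Here, the amine nitrogen carries butyl without the number moving beyond the usual scatter of repeated measurements, but no accompanying measurement explains this result.

A single substituent says little about the others that this nitrogen could carry. On these data alone, it remains open whether a methyl, a longer chain such as octyl, or an acetyl group, which would turn the amine into an amide, would also stay within the scatter of compound 1. Also unresolved is whether a second butyl on the same nitrogen, or a piperidine ring built around it, would produce a step beyond the scatter.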